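The compounds below may be only part of what the source reports. "The series", "measured", "known", "first", "only" and "open" are said of these compounds alone.

In a functional assay on MCF7 cells (Homo sapiens) for cytotoxicity, read by sulforhodamine B assay, with a stated time of 48 h, in the presence of a further agent that is not named here (a lower number here means a stronger inhibitor of growth, a higher number a weaker inhibitor of growth), compound 1 (`CC(=O)N/N=C/c1c(C)nn(-c2ccccc2)c1Oc1ccc(-c2nc3cc([N+](=O)[O-])ccc3[nH]2)cc1`) gives 40 nM and compound 2 (`Cc1nn(-c2ccccc2)c(Oc2ccc(-c3nc4cc(C(=O)O)ccc4[nH]3)cc2)c1/C=N/Nc1ccccc1`) gives 90 nM as measured values. Compound 3 (`Cc1nn(-c2ccccc2)c(Oc2ccc(-c3nc4cc(C(=O)O)ccc4[nH]3)cc2)c1/C=N/NC(N)=S`) stands at > 100000 nM in this assay and that is a limit of the assay, not a number. Compound 4 (`Cc1nn(-c2ccccc2)c(Oc2ccc(-c3nc4cc(C(N)=O)ccc4[nH]3)cc2)c1/C=N/NC(N)=S`) differs from compound 3 by one change (amino in place of hydroxy on a carbonyl carbon) that puts amino in place of hydroxy on a carbonyl carbon. Within the data shown here, no measured step covers this exchange. The nearest is an at least 1100-fold higher number from compound 2 to compound 3 (3.04 log units; beyond the scatter) and it lies on an amine nitrogen, where compound 4 keeps the group of compound 3. Only a modest move towards a lower number is therefore expected, and it may stay at the limit. The expected step is an at least 5.0-fold lower number from compound 3 to compound 4 (0.69 log units; beyond the scatter) in this assay as estimated here. Compound 4 is estimated at 20000 nM (expected range 500 nM to 100000 nM).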

Compound 4, concentration for 50% growth inhibition: > 100000 nM
Compound 4: only a limit was reported; the forecaster's own chance of this, stated with the estimate: 45%; middle value at least 5.0-fold (0.69 log units) from the limit.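

No step can be read from compound 3 to compound 4, because both stand at a limit of the assay, not a number: the limit of > 100000 nM in this assay, at which 2 of the 4 values shown sit.

From the compounds shown here alone, whether amino in place of hydroxy on the carbonyl carbon changes growth inhibition at all stays open.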